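Swapping a thiophene ring for an ethynyl group

The source may hold more compounds than are shown below. What is called first, only, known or untested is meant among the compounds shown, and "the series" means these compounds.

Compound 1 `COc1ncnc2c1c(-c1ccsc1)cn2[C@@H]1O[C@H](CO)[C@@H](O)[C@H]1O` gives 3450 nM in a functional assay on K562 cells (Homo sapiens), read by MTT assay, with a stated time of 72 h; a higher number here means a weaker inhibitor, a lower number a stronger inhibitor.
Compound 2 `CN(C)c1ncnc2c1c(-c1ccsc1)cn2[C@@H]1O[C@H](CO)[C@@H](O)[C@H]1O` reaches only a limit of this assay, > 20000 nM.
Compound 3 `COc1nc(N)nc2c1c(-c1ccsc1)cn2[C@@H]1O[C@H](CO)[C@@H](O)[C@H]1O` likewise reaches only a limit of this assay, > 20000 nM.

Among the three measured compounds, compound 1 is the only one with a definite number; the other two sit at the limit of > 20000 nM in this assay, at which 2 of the 3 values shown sit. Both measured changes to the shared core of compound 1 weaken it: an at least 5.7-fold higher number from compound 1 to compound 2 (0.76 log units; beyond the scatter) and an at least 5.7-fold higher number from compound 1 to compound 3 (0.76 log units; beyond the scatter). Compound 4 `C#Cc1cn([C@@H]2O[C@H](CO)[C@@H](O)[C@H]2O)c2ncnc(OC)c12` alters a different part of the molecule: ethynyl in place of thiophen-3-yl on an aromatic carbon. For the measured compounds named here, neither measured step touches that position, so the two known steps give no direct guide to the size or direction of this one; they show only that compound 1 tolerates changes to its core poorly, while the group exchanged here is smaller and flatter in shape. Compound 4 is therefore expected to give roughly 6000 nM, somewhere between 800 nM and 20000 nM. That estimate for compound 4 corresponds to an expected 1.7-fold higher number from compound 1 to compound 4 (0.24 log units; within the scatter), with a real chance that this assay again reports only a limit.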

Compound 4, half-maximal inhibitory concentration: 380 nM
Compound 4: middle estimate off by 16-fold (1.20 log units), on the high side; measured number outside the range, below it.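

Replacing thiophen-3-yl with ethynyl gives a 9.1-fold lower number from compound 1 to compound 4 (0.96 log units; beyond the scatter) in this assay. This is the only step shown that leads to a stronger inhibitor, whereas the two changes elsewhere on the shared core both lead to a weaker one, so this aromatic carbon is the one place shown where a change improves on compound 1, and with the methoxy group in place, a ring at this carbon is not required for activity. Nothing measured here explains why ethynyl outperforms thiophen-3-yl.

The compounds shown leave open whether ethynyl would give a similar gain alongside the dimethylamino group of compound 2 or the added amino group of compound 3. They also leave open how a longer chain such as propynyl, or a phenyl ring, would behave at this carbon.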